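A few compounds are considered here, and "the series" means these few. Any claim that something is new, unique, unknown or untested is made for them only; others in the source may bear on it.

Compound 1 `O=C1COc2ccc(-c3cnc4ccccc4c3)cc2N1c1ccccc1` is the plainest member of the set. In a functional assay on HCT-116 cells (Homo sapiens) for antiproliferative activity, read by MTT assay, with a stated time of 72 h (on this read-out lower numbers stand for stronger inhibition and higher numbers for weaker inhibition), compound 1 returns > 40000 nM, which is a limit of the assay rather than a number. Compound 2 `O=C1COc2ccc(-c3cnc(Cl)c(NS(=O)(=O)c4ccc(F)cc4)c3)cc2N1c1ccc(Cl)cc1` gives 27900 nM in this assay and holds the higher of the two numbers recorded; the nearest is compound 3 `COc1ncc(-c2ccc3c(c2)N(c2ccc(Cl)cc2)C(=O)CO3)cc1NS(=O)(=O)c1ccc(F)cc1`, which gives 19200 nM in this assay. Among the measured compounds shown here, the only single-point step measured, a 1.5-fold lower number from compound 2 to compound 3 (0.16 log units; within the scatter), lies within the scatter and concerns a different position from the one varied here. Compound 4 `O=C1COc2ccc(-c3cnc(Cl)c(NS(=O)(=O)c4ccc(F)cc4)c3)cc2N1` differs from compound 2 by hydrogen in place of 4-chlorophenyl on an amide-type nitrogen in a ring. For the measured compounds named here, no measured step touches the amide-type nitrogen, so the series gives no direct size for this change; the one measured step was within the scatter, and the whole set sits at weak potency, with one member at a limit (the limit of > 40000 nM in this assay, at which 1 of the 3 values shown sits). Compound 4 is therefore expected near 35000 nM, with a range from 12000 nM to 100000 nM. The expected step of a 1.3-fold higher number from compound 2 to compound 4 (0.10 log units; within the scatter) is small, in no confident direction, with a real chance that this assay returns only a limit.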

Compound 4, half-maximal inhibitory concentration: > 40000 nM
Compound 4: a limit, no number; the forecaster's own chance of this, stated with the estimate: 40%; at least 1.1-fold (0.05 log units) between middle value and limit.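

In this assay, among the compounds shown here, hydrogen in place of 4-chlorophenyl on the amide-type nitrogen in a ring gives the first measured step at this position: an at least 1.4-fold higher number from compound 2 to compound 4 (0.15 log units; that floor lies within the scatter). From the compounds shown here alone, compound 4 gives > 40000 nM, which is a limit of the assay and not a number, so the step is only a floor and its true size stays unknown. With this result, the limit now recurs across the series: the limit of > 40000 nM in this assay, at which 2 of the 4 values shown sit.

Going by these compounds, whether the 4-chlorophenyl group matters to the read-out at all remains open, as a floor of this size fits both a real loss and no change. Also open, on these data alone, is how a small alkyl group such as methyl, or a chain ending in an amine, would read on the same nitrogen.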